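Replacing an aryl ring by methyl on a TRPV1 antagonist core

The source may hold more compounds than are shown below. What is called first, only, known or untested is meant among the compounds shown, and "the series" means these compounds.

Measured compounds:
compound 1 `Fc1cc(-c2nc(N3CCN(c4ncccc4C(F)(F)F)CC3)[nH]c2-c2ccc(C(F)(F)F)cc2)cc(F)c1F`: 7 nM
compound 2 `Fc1cc(-c2nc(N3CCN(c4ncccc4C(F)(F)F)CC3)[nH]c2-c2cc(F)c(F)c(F)c2)cc(F)c1F`: 44 nM

In a functional assay on CHO cells for antagonist activity at transient receptor potential cation channel subfamily V member 1 (Rattus norvegicus), read by calcium flux (on this read-out higher numbers stand for weaker inhibition and lower numbers for stronger inhibition), compound 1 gives 7 nM, the lowest of the two numbers recorded. Its nearest neighbour is compound 2, which gives 44 nM; the step of a 6.3-fold higher number from compound 1 to compound 2 (0.80 log units; beyond the scatter) shows that swapping one aryl group for another at the other position of the shared core costs potency, though the change is modest.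

Compound 3 `Cc1nc(N2CCN(c3ncccc3C(F)(F)F)CC2)[nH]c1-c1ccc(C(F)(F)F)cc1` has not been measured in this assay. It differs from compound 1 in one place: methyl in place of 3,4,5-trifluorophenyl on an aromatic carbon. Among the measured compounds shown here, no measured step touches this position; the only step available, a 6.3-fold higher number from compound 1 to compound 2 (0.80 log units; beyond the scatter), concerns a different attachment point, so it offers no direct guide, and it does not rule the new change in or out. Removing a whole aromatic ring from the core and leaving only a single carbon is a larger structural change than any step recorded here, so the expectation leans toward weaker inhibition. Compound 3 is therefore expected to show a 43-fold higher number from compound 1 to compound 3 (1.63 log units; beyond the scatter), giving an estimated 300 nM with a range from 40 nM to 3000 nM.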

Compound 3, half-maximal inhibitory concentration: 628 nM
Compound 3: middle estimate off by 2.1-fold (0.32 log units), on the low side, and the stated range covers the measured number.
By their numbers in this assay, from the lowest: compound 1; then compound 2; then compound 3.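

Read in this assay the replacement of 3,4,5-trifluorophenyl by methyl is a 90-fold higher number from compound 1 to compound 3 (1.95 log units; beyond the scatter) and so gives the first direct reading at this aromatic carbon: the position responds strongly to this change, yet compound 3 still gives a measured number and not a limit of the assay. This step is larger than a 6.3-fold higher number from compound 1 to compound 2 (0.80 log units; beyond the scatter) at the other aryl position, so among the compounds shown, losing the ring here costs more than exchanging one aryl group for another there, although these are different changes at different places. No measurement at hand accounts for the loss.

The compounds shown leave open whether an aromatic ring is needed on this carbon at all, since only 3,4,5-trifluorophenyl and methyl are seen there and nothing tells how plain phenyl, cyclopropyl, ethyl or a longer chain would read. They also leave open how an amine or a carboxylic acid would read on this carbon, and whether methyl would cost as much with another group in place of 4-(trifluoromethyl)phenyl.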